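The source may hold more compounds than are shown below. What is called first, only, known or untested is meant among the compounds shown, and "the series" means these compounds.

Working notes on the series. In a functional assay on HT-29 cells (Homo sapiens) for antiproliferative activity (on this read-out lower numbers stand for stronger inhibition of growth and higher numbers for weaker inhibition of growth), compound 1 (`c1ccc(-c2cc(-c3cccnc3)nc(-c3ccccn3)c2)cc1`) gives 0.33 ug/mL and compound 2 (`c1ccc(-c2cc(-c3ccsc3)cc(-c3ccccn3)n2)nc1`) gives 0.0027 ug/mL. Compound 2 therefore holds the lower of the two numbers, and the gap lies beyond the usual scatter. Among the compounds with values here, no measured pair differs in only one place, so no direct step is available as a guide.

Compound 3 (`c1ccc(-c2cc(-c3ccsc3)cc(-c3cccnc3)n2)nc1`) has pyridin-3-yl in place of pyridin-2-yl on an aromatic carbon, next to the ring nitrogen: pyridin-3-yl in place of pyridin-2-yl on an aromatic carbon. Within the data shown here, the only measured compound carrying a pyridin-3-yl group is compound 1, at 0.33 ug/mL, which is thin support. A step to a higher number in this assay, beyond the scatter, is expected. The expected size is a 19-fold higher number from compound 2 to compound 3 (1.27 log units; beyond the scatter). For compound 3 the estimated value is 0.05 ug/mL, within a range of 0.006 ug/mL to 0.4 ug/mL.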

Compound 3, concentration for 50% growth inhibition: 0.36 ug/mL
Estimate against measurement, compound 3: 7.2-fold (0.86 log units) below, and the stated range covers the measured number.
By their numbers in this assay, from the lowest: compound 2; then compounds 1 and 3 (each within the scatter of the next).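

In this assay, this position next to the ring nitrogen now has its first direct step, and the change from pyridin-2-yl to pyridin-3-yl is large and beyond the scatter (a 130-fold higher number from compound 2 to compound 3 (2.12 log units; beyond the scatter)), although the two groups have the same counted atoms. With pyridin-3-yl held in place, thiophen-3-yl in place of phenyl leaves the two numbers indistinguishable (a 1.1-fold higher number from compound 1 to compound 3 (0.04 log units; within the scatter)), so of the two single changes shown, only the one at this position separates the compounds. Nothing measured here bears on the reason for the large step.

As far as these compounds go, it remains open whether pyridin-2-yl keeps its lower number when phenyl stands in place of thiophen-3-yl. From the compounds shown here alone, how pyridin-4-yl or a simple amine would read at this position also remains open.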